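A Urea Aryl Swap on a Weakly Inhibiting Scaffold

A few compounds are considered here, and "the series" means these few. Any claim that something is new, unique, unknown or untested is made for them only; others in the source may bear on it.

Compound 1, `O=C(Nc1ccccc1)Nc1nc(Sc2c[nH]c3ccccc23)cc(N2CCN(Cc3ccccc3)CC2)n1`: > 50000 nM
Compound 2, `O=C(Nc1ccccc1)Nc1nc(Sc2c[nH]c3ccccc23)cc(N2CCN(c3ccccn3)CC2)n1`: 30300 nM

In a functional assay on A549 cells (Homo sapiens) for inhibition, with a stated time of 72 h (on this read-out higher numbers stand for weaker inhibition and lower numbers for stronger inhibition), compound 1 reaches only a limit, > 50000 nM, not a number. Compound 1 thus stands at the limit of > 50000 nM in this assay, at which 1 of the 2 values shown sits. Compound 2 gives 30300 nM in this assay. For the measured compounds named here, the single measured step, an at least 1.6-fold lower number from compound 1 to compound 2 (0.21 log units; that floor lies within the scatter), concerns the amine nitrogen in a ring, not the amide-type nitrogen. Compound 3, `Cc1ccc(C)c(NC(=O)Nc2nc(Sc3c[nH]c4ccccc34)cc(N3CCN(Cc4ccccc4)CC3)n2)c1`, differs from compound 1 by 2,5-dimethylphenyl in place of phenyl on an amide-type nitrogen. Going by the values given here, no measured step bears on this change, so no step beyond the scatter is expected in this assay. Compound 3 is therefore estimated at 60000 nM, between 20000 nM and 180000 nM. This means an expected step that the limit leaves unreadable from compound 1 to compound 3.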

Compound 3, half-maximal inhibitory concentration: > 50000 nM
Compound 3 gave a limit, no number; the forecaster's own chance of this, stated with the estimate: 60%; the middle value is on the limit's open side.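

In this assay compound 1 and compound 3 each give only a limit, not a number, so no step between them can be read: the limit of > 50000 nM in this assay, at which 2 of the 3 values shown sit.

From the compounds shown here alone, whether 2,5-dimethylphenyl in place of phenyl on the amide-type nitrogen changes inhibition at all stays open.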